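The source may hold more compounds than are shown below. What is called first, only, known or untested is meant among the compounds shown, and "the series" means these compounds.

Compound 1 `CC(C)CNC(=C\C(=O)/C=C/c1ccc(O)cc1)/C=C/c1ccc(O)cc1` and compound 2 `COc1cc(/C=C/C(=O)CC(=O)/C=C/c2ccc(OC(C)=O)c(OC)c2)ccc1OC(C)=O` were both examined in a functional assay on EA.hy 926 cells (Homo sapiens), read by fluorescence, tested at 1 uM; on this read-out lower numbers stand for a weaker effect and higher numbers for a stronger effect at the one concentration tested. There compound 1 gives 100%, the lower of the two numbers, while compound 2 gives 114%, a gap beyond the usual scatter. Compound 3 `CCC(C)NC(=C\C(=O)/C=C/c1ccc(O)cc1)/C=C/c1ccc(O)cc1` has not yet been tested. It differs from compound 1 in one place only: sec-butyl in place of isobutyl on an amine nitrogen. The two share the same atoms, joined differently, so the alteration is modest. The step expected in this assay is no change at the digits printed from compound 1 to compound 3 (within the scatter), nothing beyond the scatter. Compound 3 is therefore expected to give about 100%, within a range from 85% to 115%.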

Compound 3, a percentage reported as activity, at one concentration (the size of the read-out at that concentration, not a potency): 99%
Compound 3: middle estimate off by 1 percentage points, on the high side; measured number inside the range.
By their numbers in this assay, from the lowest: compounds 3 and 1 (each within the scatter of the next); then compound 2.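

Swapping isobutyl for sec-butyl on an amine nitrogen in this assay gives a step of a number 1 percentage points lower from compound 1 to compound 3 (within the scatter), so this pair offers the first direct comparison at this position, and the two compounds cannot be told apart here. Moving the branch within this four-carbon chain therefore has no effect that this read-out can resolve. Nothing available explains this result. Still open, as far as these compounds go, is how a longer chain, a cyclohexyl ring or a carboxylic acid at this position would read, and whether the two compounds would also match at other concentrations.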